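The source may hold more compounds than are shown below. What is called first, only, known or untested is meant among the compounds shown, and "the series" means these compounds.

Values so far in a functional assay on HCT-8 cells (Homo sapiens) for antiproliferative activity, read by MTT assay, with a stated time of 48 h; a lower number here means a stronger inhibitor, a higher number a weaker inhibitor
compound 1 `COc1ccc2c(/C=C/C(=O)c3cc(N)c(OC)c(OC)c3)cn(C)c2c1` gives 455 nM 
compound 2 `COc1cc(C(=O)/C=C/c2c[nH]c3ccccc23)cc(SC)c1OC` gives 167 nM 
compound 3 `COc1ccc2c(/C=C/C(=O)c3cc(OC)c(OC)c(SC)c3)cn(C)c2c1` gives 157 nM 

Compound 3 sits within the scatter of compound 2, while compound 1 gives a clearly higher number. The next entry, compound 4 `COc1cc(C(=O)/C=C/c2cn(C)c3ccccc23)cc(SC)c1OC`, carries hydrogen in place of methoxy on an aromatic carbon. Going by the values given here, the one measured step (a 2.9-fold lower number from compound 1 to compound 3 (0.46 log units; beyond the scatter)) concerns a different change, so it says little here. Compound 2 (167 nM) also lacks that methoxy, with a further difference elsewhere in the core, and still matches compound 3 within the scatter. No step beyond the scatter is therefore expected in this assay, in either direction. The expected step is a 1.0-fold lower number from compound 3 to compound 4 (0.02 log units; within the scatter) and this is only an estimate. For compound 4 the estimated value is 150 nM with an expected range of 55 nM to 420 nM as a working guess.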

Compound 4, half-maximal inhibitory concentration: 210 nM
For compound 4 the middle estimate is 1.4-fold (0.15 log units) below the measured one, within the range that was stated.
By their numbers in this assay, from the lowest: compounds 3, 2 and 4 (each within the scatter of the next); then compound 1.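

In this assay, hydrogen in place of methoxy on the aromatic carbon gives a step within the scatter (a 1.3-fold higher number from compound 3 to compound 4 (0.13 log units; within the scatter)), so this methoxy is not required for activity at this level. Methyl in place of hydrogen on the aromatic nitrogen also stays within the scatter (a 1.3-fold higher number from compound 2 to compound 4 (0.10 log units; within the scatter)), which separates the two changes that compound 2 and compound 3 carried together. No measured evidence bears on either result. Open, on these data alone, is whether a chlorine atom or a carboxylic acid at this aromatic carbon, or a propyl chain on the aromatic nitrogen, would give a step beyond the scatter.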